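Amine and carbonyl linkers at the pyrazole chain end

This account rests on a few compounds, and the source may have more. Where it says the series, first, only, none or still open, it means among the compounds named here.

Measured so far in a functional assay on HCC 2998 cells (Homo sapiens) for inhibition, read by sulforhodamine B assay, with a stated time of 48 h; on this read-out higher numbers stand for weaker inhibition of growth and lower numbers for stronger inhibition of growth
compound 1 (`CCCCCCCCCCCC[C@@H](O)[C@H]1CC[C@H]([C@H](O)CCCCCCCCCCNC(=O)c2ccnn2C)O1`) gives 100000 nM
compound 2 (`CCCCCCCCCCCC[C@@H](O)[C@H]1CC[C@H]([C@H](O)CCCCCCCCCCNCc2ccnn2C)O1`) gives 1820 nM

Of the two numbers in this assay, compound 2 holds the lower. Compound 3 (`CCCCCCCCCCCC[C@@H](O)[C@H]1CC[C@H]([C@H](O)CCCCCCCCCCC(=O)Nc2ccnn2C)O1`) differs from it as follows ((1-methyl-1H-pyrazol-5-yl)carbamoyl in place of ((1-methyl-1H-pyrazol-5-yl)methyl)amino on a saturated chain carbon, ten or more bonds along the chain from an oxygen on a saturated carbon and a saturated ring carbon). Among the measured compounds shown here, only one measured step bears on this change (a 55-fold lower number from compound 1 to compound 2 (1.74 log units; beyond the scatter)), and it is large and beyond the scatter. Compound 3 again carries a carbonyl, as compound 1 does, but as a carbamoyl whose nitrogen bears the pyrazole, so that step is an imperfect guide. A large move to a higher number in this assay is therefore expected, though not necessarily all the way back to the number of compound 1 (100000 nM). The expected change is a 16-fold higher number from compound 2 to compound 3 (1.22 log units; beyond the scatter) in size. For compound 3 the estimate is 30000 nM (6000 nM to 100000 nM).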

Compound 3, concentration for 50% growth inhibition: 100000 nM
Beside the measured number, compound 3's estimate is 3.3-fold (0.52 log units) below it; the measured number falls inside the stated range.
By their numbers in this assay, from the lowest: compound 2; then compounds 1 and 3 (each within the scatter of the next).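

In this assay, replacing ((1-methyl-1H-pyrazol-5-yl)methyl)amino with (1-methyl-1H-pyrazol-5-yl)carbamoyl gives a 55-fold higher number from compound 2 to compound 3 (1.74 log units; beyond the scatter), so the large step now appears with a second carbonyl-bearing linker and not only with the (1-methyl-1H-pyrazol-5-yl)carbonyl group on the amine nitrogen. The two carbonyl forms do not separate, with no change at the digits printed from compound 1 to compound 3 (within the scatter), so whether the pyrazole sits on the carbonyl or on the nitrogen makes no visible difference here, and among these three compounds only compound 2, which has no carbonyl in the linker, stands apart. Nothing available explains this difference.

Going by these compounds, it remains open whether the lower number of compound 2 depends on the amine nitrogen itself or only on the absence of the carbonyl. An ether oxygen or a plain methylene in place of that nitrogen would separate these two readings.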